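Series notes on cytotoxicity, compound 4 pending

The source may hold more compounds than are shown below. What is called first, only, known or untested is meant among the compounds shown, and "the series" means these compounds.

Measured so far:
Compound 1, `O=c1[nH]c(SCc2cc([N+](=O)[O-])cc([N+](=O)[O-])c2)nc2ccccc12`: in an ADME assay on MRC5 cells (Homo sapiens) for cytotoxicity, read by neutral red uptake (a lower number here means that less compound is tolerated, a higher number that more compound is tolerated), compound 1 gives > 64000 nM, a limit of the assay.
Compound 2, `O=c1[nH]c(SCc2cccs2)nc2ccccc12`: in this assay compound 2 gives > 64000 nM, a limit of the assay.
Compound 3, `O=c1[nH]c(SCc2cccc([N+](=O)[O-])c2)nc2ccccc12`: in this assay compound 3 gives > 64000 nM, a limit of the assay.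

Compound 4, `O=c1[nH]c(SCc2ccc([N+](=O)[O-])s2)nc2ccccc12`, is not yet measured. From compound 3 to compound 1 the change is nitro in place of hydrogen on an aromatic carbon; the step that the two limits leave unreadable from compound 3 to compound 1 has no readable size, since both values sit at the limit (the limit of > 64000 nM in this assay, at which 3 of the 3 values shown sit). From compound 2 to compound 4 the change is nitro in place of hydrogen on an aromatic carbon, the same kind of change, though the place differs: a six-membered aromatic ring of carbon only, meta to a large group and meta to a nitro group, against a five-membered aromatic ring with one sulfur, next to the ring sulfur, two ring bonds from the ring atom that bears a large group. The difference between the cores of compound 2 and compound 3 is not broken down here.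

Because every value shown sits at the limit (the limit of > 64000 nM in this assay, at which 3 of the 3 values shown sit), compound 4 is expected to give 80000 nM in this assay. The expected range for compound 4 runs from 30000 nM to 200000 nM. The expected step that the limit leaves unreadable from compound 2 to compound 4 is most likely, like a step that the two limits leave unreadable from compound 3 to compound 1, to be one the limit leaves unreadable.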

Compound 4, half-maximal cytotoxic concentration: > 64000 nM
Compound 4 gave a limit, no number; the forecaster's own chance of this, stated with the estimate: 75%; the middle value is on the limit's open side.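

No new step can be read from compound 2 to compound 4 in this assay, since both values are limits of the assay: the limit of > 64000 nM in this assay, at which 4 of the 4 values shown sit.

The compounds shown leave open whether nitro in place of hydrogen on an aromatic carbon alters the read-out at all, and at what concentration any of the four compounds turns cytotoxic.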